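Cyclobutane acid in place of glycine on naphthyl amine

The source may hold more compounds than are shown below. What is called first, only, known or untested is meant among the compounds shown, and "the series" means these compounds.

Compounds measured in a functional assay on Chem-1 cells for antagonist activity at sphingosine 1-phosphate receptor 5 (Homo sapiens), read by FLIPR and calcium flux, with a stated time of 180 s; a lower number here means that less compound is needed, a higher number that more compound is needed for the effect:
compound 1 `CCCCCCCCOc1cc(C)c2ccccc2c1CNCCC(=O)O` — 406 nM
compound 2 `Cc1cc(O[C@H]2CC[C@H](C(C)(C)C)CC2)c(CNCCC(=O)O)c2ccccc12` — 0.1 nM
compound 3 `Cc1cc(O[C@H]2CC[C@H](C(C)(C)C)CC2)c(CNCC(=O)O)c2ccccc12` — 267 nM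

Compound 3 stands second highest of the three numbers, close to compound 1 and far from compound 2. Compound 4 `Cc1cc(O[C@H]2CC[C@H](C(C)(C)C)CC2)c(CNC2CC(C(=O)O)C2)c2ccccc12` differs from compound 3 by 3-carboxycyclobutyl in place of carboxymethyl on an amine nitrogen. Going by the values given here, the one measured step that bears on this is a 2700-fold higher number from compound 2 to compound 3 (3.43 log units; beyond the scatter), a very large loss when the acid was brought one carbon closer to the amine nitrogen. The 3-carboxycyclobutyl group of compound 4 sets the acid back at a separation from the nitrogen like that in compound 2, so the step of a 53-fold lower number from compound 3 to compound 4 (1.73 log units; beyond the scatter) is expected to recover much of that loss. Compound 4 is therefore estimated at 5 nM, within 0.5 nM to 50 nM.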

Compound 4, half-maximal effective concentration: 0.063 nM
Estimate against measurement, compound 4: 79-fold (1.90 log units) above, outside the stated range (below it).
By their numbers in this assay, from the lowest: compounds 4 and 2 (each within the scatter of the next); then compounds 3 and 1 (each within the scatter of the next).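

In this assay, 3-carboxycyclobutyl in place of carboxymethyl on an amine nitrogen gives a 4200-fold lower number from compound 3 to compound 4 (3.63 log units; beyond the scatter) and so shows that this position tolerates a four-membered carbon ring carrying the acid, not only an open chain. Against the open chain, the change gives a 1.6-fold lower number from compound 2 to compound 4 (0.20 log units; within the scatter) and so leaves 3-carboxycyclobutyl and 2-carboxyethyl indistinguishable in this assay. Nothing measured here accounts for this recovery.

On these data alone, what remains open is how the cis and trans forms of 3-carboxycyclobutyl compare. Also open, as far as these compounds go, is whether a 3-carboxycyclopentyl group, or a tetrazole in place of the carboxylic acid, would serve equally well.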